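Pyrimidinyl in place of dichlorophenyl on a piperazine amide

The source may report more compounds than this note shows. Statements on the series, on what has been measured and on what is new or still open speak of the compounds shown alone.

Compound 1 `CC1(c2ccccc2)CC(=O)N(CC(=O)N2CCN(c3ccccc3Cl)CC2)C1=O`: "not active" (no number reported)
Compound 2 `CC1(c2ccccc2)CC(=O)N(CC(=O)N2CCN(c3ccc(Cl)c(Cl)c3)CC2)C1=O`: 300 mg/kg

Two compounds share one core and differ only in the aryl group on the ring nitrogen. In a functional assay on the whole organism (strain CD-1) with Mus musculus as the target, in the maximal electroshock model, with a stated time of 2 h (a higher number here means that more compound is needed for the effect, a lower number that less compound is needed), compound 1 is recorded as "not active" (no number reported). Within the data shown here, compound 2 gives 300 mg/kg, the only number in the set, so it stands alone and has nothing to be ranked against. Compound 3 `CC1(c2ccccc2)CC(=O)N(CC(=O)N2CCN(c3ncccn3)CC2)C1=O` has not been measured; it carries pyrimidin-2-yl in place of 3,4-dichlorophenyl on an amine nitrogen in a ring. Among the measured compounds shown here, no step between measured compounds is available to guide this change, and the set gives only one number. Compound 3 is therefore expected to stay close to compound 2, a step of no change at the digits printed from compound 2 to compound 3 (within the scatter) meaning no change beyond the scatter, with a real chance that no number is obtained at all. The estimate for compound 3 is 300 mg/kg, within a range from 100 mg/kg to 1000 mg/kg.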

Compound 3, minimum effective dose: "not active" (no number reported)
Compound 3 has no reported number here, and the estimate cannot be compared.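

In this assay, among these compounds, compound 3 gives "not active" (no number reported), so no step from compound 2 to compound 3 can be read. No measured evidence shown here bears on this result. The compounds shown leave open how the minimum effective dose with pyrimidin-2-yl compares with that with 3,4-dichlorophenyl.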